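A Chloro Added to an Inactive Benzamide

This account rests on a few compounds, and the source may have more. Where it says the series, first, only, none or still open, it means among the compounds named here.

Measured in a functional assay on MDA-MB-231 cells (Homo sapiens), read by microscopy and transwell migration, with a stated time of 24 h; on this read-out higher numbers stand for weaker inhibition and lower numbers for stronger inhibition:
- Compound 1 `CCCCCCn1c(-c2ccc(C)cc2C)cs/c1=N\C(=O)c1ccccc1`: 45 nM
- Compound 2 `O=C(Nc1nc(-c2cccc(Br)c2)cs1)c1ccccc1`: 10000 nM
- Compound 3 `COc1cc(-c2csc(NC(=O)c3ccccc3)n2)cc(OC)c1OC`: > 50000 nM

Compound 3 gives > 50000 nM, and this is a limit of the assay, not a number. That places it at the weak end of the data: the limit of > 50000 nM in this assay, at which 1 of the 3 values shown sits.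

Compound 4 `COc1cc(-c2csc(NC(=O)c3ccc(Cl)cc3)n2)cc(OC)c1OC` is compound 3 with one change: chloro in place of hydrogen on an aromatic carbon, para to a large group, which turns the benzoyl into (4-chlorophenyl)carbonyl. Counted out, the change is chloro in place of hydrogen on an aromatic carbon.

Going by the values given here, no two measured compounds differ in only one place, so the size of such a change has not been seen in this assay. Compound 1 gives 45 nM and compound 2 gives 10000 nM, but they differ from each other in more than one place, so their gap cannot be carried over to this change. A small shift toward stronger inhibition is the expectation, and compound 4 may well stay at the limit. The expected step of an at least 1.6-fold lower number from compound 3 to compound 4 (0.22 log units; that floor lies within the scatter) is therefore modest. For compound 4 the estimated value is 30000 nM, with an expected range of 5000 nM to 100000 nM.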

Compound 4, half-maximal inhibitory concentration: > 25000 nM
Compound 4 was reported as a limit (the forecaster's own chance of this, stated with the estimate: 45%); the middle value does not contradict the limit.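

In this assay compound 3 gives > 50000 nM, which is a limit and not a number. Compound 4 gives > 25000 nM, also a limit, so no step can be read between compound 3 and compound 4. The compounds shown leave open whether chloro in place of hydrogen on an aromatic carbon changes inhibition at all, and by how much.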